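The source may hold more compounds than are shown below. What is called first, only, known or untested is meant among the compounds shown, and "the series" means these compounds.

Compound 1 `CC(=O)Oc1c(O)cc2oc(-c3ccccc3)cc(=O)c2c1O` gives 11000 nM in a functional assay on KB 3-1 cells (Homo sapiens), with a stated time of 1 h; a higher number here means that more compound is needed for the effect, a lower number that less compound is needed.
Compound 2 `CC(=O)Oc1cc2oc(-c3ccccc3)cc(=O)c2c(O)c1OC(C)=O` gives 9700 nM in this assay.
Compound 3 `COc1cc2oc(-c3ccccc3)cc(=O)c2c(OC)c1OC(C)=O` gives 11500 nM in this assay.

Going by the values given here, compound 1 stands second highest of the three numbers, yet every gap between it and the others lies within the scatter, so no compound can be set apart. Compound 4 `CCCOc1c(O)cc2oc(-c3ccccc3)cc(=O)c2c1O` differs from compound 1 by propyl in place of acetyl on an oxygen on an aromatic ring. Among the compounds with values here, the only measured step that alters a group on an oxygen on an aromatic ring is a 1.1-fold lower number from compound 1 to compound 2 (0.05 log units; within the scatter), and it stayed within the scatter; no measured step exchanges acetyl for propyl. On this basis, a step within the scatter is expected, no change at the digits printed from compound 1 to compound 4 (within the scatter). Compound 4 is therefore estimated at 11000 nM, with a range from 4000 nM to 30000 nM.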

Compound 4, half-maximal effective concentration: 2000 nM
Estimate against measurement, compound 4: 5.5-fold (0.74 log units) above; the measured number lies below the stated range.
By their numbers in this assay, from the lowest: compound 4; then compounds 2, 1 and 3 (each within the scatter of the next).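

Exchanging acetyl for propyl on this oxygen gives a 5.5-fold lower number from compound 1 to compound 4 (0.74 log units; beyond the scatter) in this assay, the only step shown that lies beyond the scatter. The number therefore responds to the group held on this oxygen, which the acetyl-for-hydrogen step among the earlier compounds had not shown. No measurement bears on why the number moved, so the change cannot be tied to a cause. Going by these compounds, whether a longer chain such as butyl or a chain ending in an amine would move the number further remains open. So does whether propyl on another oxygen of the shared core would give a similar step.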